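Homologating the oxolane amine on a shared core

A few compounds are considered here, and "the series" means these few. Any claim that something is new, unique, unknown or untested is made for them only; others in the source may bear on it.

Among the compounds with values here, compound 1 `Cn1cc(-c2ccc3nnc(Sc4ccc5ncc(N6CCC(N)C6)cc5c4)n3c2)cn1` is the only compound here whose result in an ADME assay on cytosol from liver (strain CD1) for pharmacokinetics, with aldehyde oxidase 1 (Mus musculus) as the target, read by LC-MS, with a stated time of 120 min, tested at 1 uM (a lower number here means that the compound disappears faster, a higher number that the compound lasts longer), is a limit rather than a number, at > 8.33 h. Within the data shown here, compound 2 `Cn1cc(-c2ccc3nnc(Sc4ccc5ncc(NC6CCOC6)cc5c4)n3c2)cn1` gives 0.85 h in this assay and is thus the sole numerical value shown. The step of an at least 9.8-fold lower number from compound 1 to compound 2 (0.99 log units; beyond the scatter) is the only measured one. Compound 3 `Cn1cc(-c2ccc3nnc(Sc4ccc5ncc(NCC6CCOC6)cc5c4)n3c2)cn1` differs from compound 2 by (oxolan-3-yl)methyl in place of oxolan-3-yl on a nitrogen on an aromatic ring. That measured step concerns a different exchange and bears only loosely on this one, so a step within the scatter is expected, a 1.2-fold higher number from compound 2 to compound 3 (0.07 log units; within the scatter). Compound 3 is therefore estimated at 1 h, between 0.4 h and 2.5 h.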

Compound 3, half-life: 1.63 h
Beside the measured number, compound 3's estimate is 1.6-fold (0.21 log units) below it; the measured number falls inside the stated range.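

In this assay, the homologation on this nitrogen gives a 1.9-fold higher number from compound 2 to compound 3 (0.28 log units; within the scatter), so the added carbon does not separate the two oxolane amines. The exchange at the aromatic carbon gives an at least 5.1-fold lower number from compound 1 to compound 3 (0.70 log units; beyond the scatter), which shows that the ((oxolan-3-yl)methyl)amino group, like the (oxolan-3-yl)amino group, remains clearly apart from 3-aminopyrrolidin-1-yl. The result for compound 1 is a limit, not a number: the limit of > 8.33 h in this assay, at which 1 of the 3 values shown sits.

From the compounds shown here alone, whether a longer chain on this nitrogen, or a primary amine on the oxolane ring, would shift the half-life beyond the scatter remains open.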